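Adding One Carbon to the Chain of Compound 2

This account rests on a few compounds, and the source may have more. Where it says the series, first, only, none or still open, it means among the compounds named here.

Compound 1 `CCCCNC(=O)[C@H]1OC(n2cnc3c(N)ncnc32)[C@H](O)[C@@H]1O` and compound 2 `CCCCCCCCNC(=O)[C@H]1OC(n2cnc3c(N)ncnc32)[C@H](O)[C@@H]1O` share the same core and differ only in the length of the chain attached to the amide nitrogen. In an assay on cell membranes for binding affinity to 2-oxoglutarate receptor 1 (Rattus norvegicus), read by radioligand binding (on this read-out lower numbers stand for stronger inhibition and higher numbers for weaker inhibition), compound 1 gives 17 nM, and compound 2 gives 21 nM. Compound 2 thus carries the higher of the two numbers, yet the step of a 1.2-fold higher number from compound 1 to compound 2 (0.09 log units; within the scatter) shows that the two values cannot be told apart.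

Compound 3 `CCCCCCCCCNC(=O)[C@H]1OC(n2cnc3c(N)ncnc32)[C@H](O)[C@@H]1O` has not yet been measured; it differs from compound 2 by methyl in place of hydrogen on a saturated chain carbon, eight bonds along the chain from an amide-type nitrogen. For the measured compounds named here, the only measured step that bears on this change is the lengthening by four carbons between compound 1 and compound 2, which stayed within the scatter, so adding a single carbon is expected to bring no shift beyond the scatter in this assay, an expected step of a 1.0-fold higher number from compound 2 to compound 3 (0.02 log units; within the scatter). Compound 3 is therefore estimated at 22 nM, with a range from 10 nM to 50 nM.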

Compound 3, inhibition constant: 31 nM
Estimate against measurement, compound 3: 1.4-fold (0.15 log units) below, within the range that was stated.
By their numbers in this assay, from the lowest: compounds 1, 2 and 3 (each within the scatter of the next).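

Methyl in place of hydrogen, eight bonds along the chain from an amide-type nitrogen, gives a 1.5-fold higher number from compound 2 to compound 3 (0.17 log units; within the scatter) in this assay and so shows that this position accepts one more carbon with no shift that can be told from ordinary assay noise. The pentyl change, four bonds along the chain from an amide-type nitrogen, gives a 1.8-fold higher number from compound 1 to compound 3 (0.26 log units; within the scatter) and so shows that the full range of chain lengths shown here, from butyl on the amide nitrogen upward, still sits inside the scatter. No measurement here accounts for how closely these numbers agree.

From the compounds shown here alone, whether a still longer chain would stay within the scatter remains open. Also open, going by these compounds, is how an amine or a carboxylic acid at this same position would read in this assay compared with the plain methyl.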